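A Nitro Group Enters Where Bromo Once Stood

The source may report more compounds than this note shows. Statements on the series, on what has been measured and on what is new or still open speak of the compounds shown alone.

Compound 1 `CCC1S/C(=N\N=C\c2c(-c3ccc(Br)cc3)[nH]c3ccccc23)NC1=O` gives 5910 nM in an ADME assay on MRC5 cells (Homo sapiens) for cytotoxicity, read by fluorescence, with a stated time of 24 h; a higher number here means a weaker inhibitor, a lower number a stronger inhibitor.
Compound 2 `CCC1S/C(=N\N=C\c2c(-c3ccccc3)[nH]c3ccccc23)NC1=O` reaches only the limit > 50000 nM in this assay.

Compound 2 therefore stands at a limit of this assay, (the limit of > 50000 nM in this assay, at which 1 of the 2 values shown sits), without an exact number. Compound 3 `CCC1S/C(=N\N=C\c2c(-c3ccc([N+](=O)[O-])cc3)[nH]c3ccccc23)NC1=O` differs from compound 2 by nitro in place of hydrogen on an aromatic carbon. Among the compounds with values here, the only measured step, an at least 8.4-fold higher number from compound 1 to compound 2 (0.92 log units; beyond the scatter), raised the number; nitro in place of hydrogen is a different change, and no step with nitro is known. A modest decrease is nevertheless expected for compound 3, an at least 3.3-fold lower number from compound 2 to compound 3 (0.52 log units; beyond the scatter), because an at least 8.4-fold higher number from compound 1 to compound 2 (0.92 log units; beyond the scatter) pointed the other way. Compound 3 is estimated at 15000 nM, within 4000 nM to 50000 nM.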

Compound 3, half-maximal inhibitory concentration: 25200 nM
Estimate against measurement, compound 3: 1.7-fold (0.23 log units) below; measured number inside the range.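

With nitro at this place on the ring, compound 3 gives an exact number, while compound 2 stands only at a limit: the limit of > 50000 nM in this assay, at which 1 of the 3 values shown sits. The change therefore reads only as a floor, an at least 1.9-fold lower number from compound 2 to compound 3 (0.29 log units; that floor lies within the scatter), so even its size stays uncertain. Nitro and bromo are also not interchangeable here, since the swap gives a 4.3-fold higher number from compound 1 to compound 3 (0.63 log units; beyond the scatter) in this assay. On these data alone, whether an amine or a carboxylic acid at this place would sit nearer compound 1 or compound 3 remains open, and so does the exact size of any gain over hydrogen.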